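The compounds below may be only part of what the source reports. "The series", "measured", "known", "first", "only" and "open" are said of these compounds alone.

Working notes on the triazole series. Compound 1 `CCCC[C@@H](CCn1cncn1)c1ccccc1` in an ADME assay on HEp-2 cells (Homo sapiens) for cytotoxicity, read by MTT assay, with a stated time of 3 days (on this read-out lower numbers stand for higher toxicity in this test and higher numbers for lower toxicity in this test), gives 40.8 ug/mL. Compound 2 `CCCC[C@H](CCn1cncn1)c1ccc(OC)cc1` in this assay gives 34.5 ug/mL; the two numbers sit within the usual scatter of each other, so no order between compound 1 and compound 2 can be read from them. For the measured compounds named here, no step between measured compounds is on hand, and neither is one that alters the configuration at the chain carbon.

Compound 3 `CCCC[C@@H](CCn1cncn1)c1ccc(OC)cc1` is the next entry for this assay. Relative to compound 2 the change is the two compounds have the same atoms and bonds and differ only in configuration as drawn: 1 of 1 stereo elements differ; a stereocentre at a saturated chain carbon is drawn R in compound 2 and S in compound 3. Nothing in the two figures so far speaks for either direction, since both measured compounds share one drawn configuration. The step from compound 2 to compound 3 in this assay is therefore expected to be a 1.0-fold higher number from compound 2 to compound 3 (0.01 log units; within the scatter), that is, none beyond the scatter. For compound 3 the expected value in this assay is 35 ug/mL, with a range from 18 ug/mL to 65 ug/mL.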

Compound 3, half-maximal cytotoxic concentration: 31.6 ug/mL
The estimate for compound 3 lay 1.1-fold (0.04 log units) above the measured number, within the range that was stated.
By their numbers in this assay, from the lowest: compounds 3, 2 and 1 (each within the scatter of the next).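

In this assay the chain carbon can now be read in both drawn configurations, and inverting it gives a 1.1-fold lower number from compound 2 to compound 3 (0.04 log units; within the scatter), so for this pair the configuration at this position brings no step beyond the scatter. The aromatic position also has its first direct step, since methoxy in place of hydrogen on an aromatic carbon gives a 1.3-fold lower number from compound 1 to compound 3 (0.11 log units; within the scatter), which likewise stays inside the scatter. The first of these readings is free of any other structural change: the fact that compounds 2 and 3 differ only in the configuration as drawn.

On these data alone, whether an amine or a carboxylic acid in place of the methoxy, or a longer chain at the stereocentre, would give a step beyond the scatter stays open. So does whether the two configurations would stay this close with such a group present.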